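The compounds below may be only part of what the source reports. "The series", "measured", "known", "first", "only" and "open" are said of these compounds alone.

Going by the values given here, compound 2 `CCCCOC(=O)NS(=O)(=O)c1ccc(CCC)cc1-c1ccc(Cn2c(C(C)(C)C)nc3ccccc32)cc1` gives 5.3 nM in an assay on membranes from HEK293 cells for displacement of a labelled ligand from Type-2 angiotensin II receptor (Homo sapiens), read by radioligand binding (on this read-out higher numbers stand for weaker inhibition and lower numbers for stronger inhibition), the lowest of the three numbers measured so far. Compound 1 `CCCCOC(=O)NS(=O)(=O)c1ccc(CCC)cc1-c1ccc(Cn2c(C3CCCC3)nc3ccccc32)cc1` gives 35 nM in this assay, and compound 3 `CCCCOC(=O)NS(=O)(=O)c1ccc(CCC)cc1-c1ccc(Cn2c(C3CC3)nc3ccccc32)cc1` gives 31 nM in this assay. The steps of a 6.6-fold lower number from compound 1 to compound 2 (0.82 log units; beyond the scatter) and a 5.8-fold higher number from compound 2 to compound 3 (0.77 log units; beyond the scatter) lie beyond the scatter, whereas a 1.1-fold lower number from compound 1 to compound 3 (0.05 log units; within the scatter) lies within it. Compound 4 `CCCc1ccc(S(=O)(=O)NC(=O)OCCCC(F)(F)F)c(-c2ccc(Cn3c(C(C)(C)C)nc4ccccc43)cc2)c1` differs from compound 2 by trifluoromethyl in place of methyl on a saturated chain carbon, three bonds along the chain from an oxygen next to a carbonyl group. Among the compounds with values here, all three measured steps concern the group on an aromatic carbon and none touches the chain, so no measured step bears directly on this change. Compound 4 is therefore expected to show no step beyond the scatter, a 1.1-fold higher number from compound 2 to compound 4 (0.05 log units; within the scatter). The estimate for compound 4 in this assay is 6 nM, with a range from 2 nM to 18 nM.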

Compound 4, inhibition constant: 4.5 nM
For compound 4 the middle estimate is 1.3-fold (0.12 log units) above the measured one; the range from low to high includes it.
By their numbers in this assay, from the lowest: compounds 4 and 2 (each within the scatter of the next); then compounds 3 and 1 (each within the scatter of the next).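

In this assay, trifluoromethyl in place of methyl on a saturated chain carbon, three bonds along the chain from an oxygen next to a carbonyl group, gives a 1.2-fold lower number from compound 2 to compound 4 (0.07 log units; within the scatter). Going by these compounds alone, this is the first measured change on the chain, and it shows that replacing methyl with trifluoromethyl at this position leaves the number within the scatter. No measurement shown offers an explanation for this result. Going by these compounds, whether an amine, a carboxylic acid or a longer chain at this position would also leave the number within the scatter stays open. So does whether the same change behaves alike with cyclopentyl or cyclopropyl in place of tert-butyl on the aromatic carbon.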